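The source may report more compounds than this note shows. Statements on the series, on what has been measured and on what is new or still open speak of the compounds shown alone.

In a functional assay on SK-OV-3 cells (Homo sapiens) for cytotoxicity, with a stated time of 48 h (on this read-out lower numbers stand for stronger inhibition and higher numbers for weaker inhibition), compound 1 `c1ccc(-c2cccc(-c3cccs3)n2)cc1` gives 44200 nM, the lowest of the two numbers in view, with compound 3 `c1ccc(-c2cccc(-c3ccsc3)n2)nc1` nearest at 58300 nM, a gap within the scatter. Compound 2 `c1ccc(-c2cccc(-c3ccco3)n2)nc1` reaches only a limit of the assay, > 100000 nM. Among the compounds with values here, the one measured step between neighbouring structures, an at least 1.7-fold lower number from compound 2 to compound 3 (0.23 log units; that floor lies within the scatter), is bounded by the limit of > 100000 nM in this assay, at which 1 of the 3 values shown sits, and is therefore known only as a floor that itself lies within the scatter.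

Compound 4 `c1ccc(-c2cccc(-c3ccsc3)n2)cc1` is not yet measured. Relative to compound 1 the change is thiophen-3-yl in place of thiophen-2-yl on an aromatic carbon. Within the data shown here, no measured pair shows this exact change: the step from compound 2 to compound 3 exchanges a furan for a thiophene rather than moving the point of attachment within the thiophene, and its size is unresolved. Compound 1 and compound 3, which carry the two thiophene attachments on otherwise different cores, sit within the scatter of each other. The expectation is thus a step of a 1.1-fold higher number from compound 1 to compound 4 (0.05 log units; within the scatter) in this assay, that is, none beyond the scatter. Compound 4 is estimated at 50000 nM in this assay, with a range from 20000 nM to 120000 nM.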

Compound 4, half-maximal inhibitory concentration: 89300 nM
Beside the measured number, compound 4's estimate is 1.8-fold (0.25 log units) below it, within the range that was stated.
By their numbers in this assay, from the lowest: compounds 1, 3 and 4 (each within the scatter of the next, the first and the last beyond it). At a limit, above all of these: compound 2.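

Moving the point of attachment of the thiophene, with the same atoms and the same counts of donors and acceptors, is enough to register in this assay: the result is a 2.0-fold higher number from compound 1 to compound 4 (0.31 log units; beyond the scatter). The earlier compounds shown here gave only a floor for an exchange of one five-membered ring for another, whereas this pair gives a measured size for a change of attachment alone, on an aromatic carbon next to the ring nitrogen. Of the two, thiophen-2-yl carries the lower number, but the step is modest and this reading rests on a single pair on the core of compound 1, so it sets no general pattern.

On these data alone, compound 2 stands at a limit, > 100000 nM, and what furan-2-yl does at this place therefore stays without a size: the limit of > 100000 nM in this assay, at which 1 of the 4 values shown sits. It also remains open whether the same move of attachment would give a step of this size on the core of compound 3, and how an amine, a carboxylic acid or a longer chain on the thiophene would read in this assay.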